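Halogenated phenyl groups and microsomal half-life in dog

A few compounds are considered here, and "the series" means these few. Any claim that something is new, unique, unknown or untested is made for them only; others in the source may bear on it.

Compound 1 `N#Cc1ccc(-c2nc(NCCNc3ccc([N+](=O)[O-])c(N)n3)ncc2-c2ncc[nH]2)cc1` was tested in an ADME assay on microsomes from liver (Canis lupus familiaris) for metabolic stability; on this read-out higher numbers stand for a longer-lived compound and lower numbers for a shorter-lived compound. In this assay compound 1 gives > 0.5 h, which is a limit of the assay rather than a measured number. Two close analogues carry a different aryl group on the shared core. Compound 2 `Nc1nc(NCCNc2ncc(-c3ncc[nH]3)c(-c3ccc(F)cc3F)n2)ccc1[N+](=O)[O-]` bears a 2,4-difluorophenyl in place of the 4-cyanophenyl; in this assay compound 2 gives > 0.5 h, again a limit. Compound 3 `Nc1nc(NCCNc2ncc(-c3ncc[nH]3)c(-c3ccc(F)cc3Cl)n2)ccc1[N+](=O)[O-]` carries a 2-chloro-4-fluorophenyl; in this assay compound 3 gives > 0.5 h, also a limit. Consequently the step that the two limits leave unreadable from compound 1 to compound 2, the step that the two limits leave unreadable from compound 1 to compound 3 and the step that the two limits leave unreadable from compound 2 to compound 3 cannot be sized, since all three compounds sit at the limit of > 0.5 h in this assay, at which 3 of the 3 values shown sit.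

Compound 4 `Nc1nc(NCCNc2ncc(-c3ncc[nH]3)c(-c3ccc(Cl)cc3Br)n2)ccc1[N+](=O)[O-]` continues this series of aryl replacements: 2-bromo-4-chlorophenyl in place of 4-cyanophenyl on an aromatic carbon. The measured steps that bear on it are the two aryl exchanges from compound 1 and the halogen exchange between compound 2 and compound 3. None of them has a readable size. He therefore expects the step that the limit leaves unreadable from compound 1 to compound 4 to be small and most likely to leave compound 4 at the same limit. His estimate for compound 4 in this assay is 1 h, with a range from 0.5 h to 3 h.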

Compound 4, half-life: > 0.5 h
Compound 4: a limit, no number; the forecaster's own chance of this, stated with the estimate: 70%; the middle value is on the limit's open side.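

In this assay compound 4 gives > 0.5 h which is again a limit of the assay and not a number. Among the compounds shown here, no step between compound 4 and compound 1, compound 2 or compound 3 can be read, because all four compounds stand at the same limit: the limit of > 0.5 h in this assay, at which 4 of the 4 values shown sit.

The compounds shown leave open the actual half-life of each compound and whether exchanging the aryl group changes it at all.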